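2,6-Dichlorophenyl to 4-fluorophenyl: an untested exchange

The compounds below may be only part of what the source reports. "The series", "measured", "known", "first", "only" and "open" are said of these compounds alone.

Three compounds have been measured so far in a functional assay on Caco-2 cells (Homo sapiens) for inhibition, read by MTT assay, with a stated time of 48 h, tested at 10 uM (a lower number here means less inhibition of growth, a higher number more inhibition of growth at the concentration tested), and give these values:

- compound 1 `Cc1cc(=O)c2c(O)c(CN3CCCC3CO)c(O)c([C@H]3CCN(C)C[C@H]3O)c2o1` 19%
- compound 2 `Cc1cc(=O)c2c(O)c(CN(C(C)C)C(C)C)c(O)c([C@H]3CCN(C)C[C@H]3O)c2o1` 22%
- compound 3 `Cc1oc2c([C@H]3CCN(C)C[C@H]3O)c(O)cc(O)c2c(=O)c1C(O)c1c(Cl)cccc1Cl` 24%

Compound 3, at 24%, lies within the scatter of both compound 1 and compound 2, so the three values cannot be told apart. The next compound, compound 4 `Cc1oc2c([C@H]3CCN(C)C[C@H]3O)c(O)cc(O)c2c(=O)c1C(O)c1ccc(F)cc1`, has yet to be measured. It carries 4-fluorophenyl in place of 2,6-dichlorophenyl on a saturated chain carbon bound to an aromatic carbon and an oxygen on a saturated carbon and is otherwise the same as compound 3.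

Within the data shown here, only one measured step exists, and it exchanges a different pair of groups, diisopropylamino in place of 2-(hydroxymethyl)pyrrolidin-1-yl. That step, a number 3 percentage points higher from compound 1 to compound 2 (within the scatter), stayed within the scatter. Among the measured compounds shown here, no measured step touches the phenyl group itself, so this evidence is indirect and the range must stay wide. The estimated step is a number 1 percentage points lower from compound 3 to compound 4 (within the scatter) and nothing beyond the scatter is expected. Compound 4 is estimated at 23% in this assay (range 11% to 38%), and that remains an expectation until the measurement is made.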

Compound 4, percent growth inhibition at one concentration: 11%
Compound 4: the middle estimate sits 12 percentage points above what was measured, within the range that was stated.
By their numbers in this assay, from the lowest: compounds 4, 1, 2 and 3 (each within the scatter of the next, the first and the last beyond it).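

In this assay, among these compounds, the carbon described as a saturated chain carbon bound to an aromatic carbon and an oxygen on a saturated carbon proved sensitive to the group it carries: exchanging 2,6-dichlorophenyl for 4-fluorophenyl gave a number 13 percentage points lower from compound 3 to compound 4 (beyond the scatter) and was the first step to leave the scatter, whereas the exchange of amines gave only a number 3 percentage points higher from compound 1 to compound 2 (within the scatter) at a different place on the shared core. The exchange alters the kind of halogen, the number of halogens and their placement on the phenyl ring all at once, with the heavy atom count of the group going from 8 to 7, so this single step cannot assign the drop to any one of these alterations. No measurement offered here explains the drop.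

As far as these compounds go, it remains open whether the drop follows from the chlorine atoms leaving or from the fluorine entering, a question that an unsubstituted phenyl, a 2,6-difluorophenyl or a 4-chlorophenyl at the same carbon would address. Also unknown is how a ring holding nitrogen, such as pyridyl, or an amine in place of the ring would read in this assay at this position.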